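From Methyl to Fluoro on the Phenylamino Group

A few compounds are considered here, and "the series" means these few. Any claim that something is new, unique, unknown or untested is made for them only; others in the source may bear on it.

Compound 1 `Cc1cc(N2CCNCC2)nc(SCc2nc3ccccc3[nH]2)n1` in a functional assay on MGC-803 cells (Homo sapiens) for cytotoxicity, read by MTT assay, with a stated time of 72 h (on this read-out higher numbers stand for weaker inhibition and lower numbers for stronger inhibition), gives a limit rather than a number, > 100000 nM.
Compound 2 `Cc1cc(Nc2ccc(Br)cc2)nc(SCc2nc3ccccc3[nH]2)n1` gives 26800 nM.
Compound 3 `Cc1ccc(Nc2cc(C)nc(SCc3nc4ccccc4[nH]3)n2)cc1` gives 7390 nM.

Among the two plain numbers, compound 3 stands lower, set apart by a 3.6-fold lower number from compound 2 to compound 3 (0.56 log units; beyond the scatter). Compound 4 `Cc1cc(Nc2ccc(F)cc2)nc(SCc2nc3ccccc3[nH]2)n1` differs from compound 3 by fluoro in place of methyl on an aromatic carbon. Going by the values given here, no measured step swaps methyl for fluoro; the closest is a 3.6-fold lower number from compound 2 to compound 3 (0.56 log units; beyond the scatter), where a halogen instead of methyl went with the higher number. A halogen entering again makes a somewhat higher number plausible for compound 4, but fluoro is not bromo, so the step may also stay within the scatter. Compound 4 is therefore expected at 12000 nM, between 5000 nM and 30000 nM. The expected step is a 1.6-fold higher number from compound 3 to compound 4 (0.21 log units; within the scatter).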

Compound 4, half-maximal inhibitory concentration: 5770 nM
Compound 4: the middle estimate sits 2.1-fold (0.32 log units) above what was measured; the measured number falls inside the stated range.
By their numbers in this assay, from the lowest: compounds 4 and 3 (each within the scatter of the next); then compound 2. At a limit, above all of these: compound 1.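

Fluoro in place of methyl changes little at this position (a 1.3-fold lower number from compound 3 to compound 4 (0.11 log units; within the scatter)), so a halogen here does not by itself go with a higher number. Bromo is the group that stands apart (a 4.6-fold lower number from compound 2 to compound 4 (0.67 log units; beyond the scatter)), and (4-fluorophenyl)amino keeps the clear separation from piperazin-1-yl (an at least 17-fold lower number from compound 1 to compound 4 (1.23 log units; beyond the scatter)). That last step starts from a limit for compound 1, not a plain number: the limit of > 100000 nM in this assay, at which 1 of the 4 values shown sits.

From the compounds shown here alone, whether chloro would sit level with fluoro or with bromo remains open. So does whether methoxy, an amine or a carboxylic acid at this position would be tolerated.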